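Swapping the aryl group on a dihydropyridine core

The compounds below may be only part of what the source reports. "The series", "measured", "known", "first", "only" and "open" are said of these compounds alone.

Of the compounds shown here, three sharing one core have been measured in a functional assay (muscle tissue) with Cavia porcellus as the target; a higher number here means that more compound is needed for the effect, a lower number that less compound is needed. Compound 1 `COC(=O)C1=C(C)N=C(C)/C(=C(\O)OC)C1c1cccc(O)c1` gives 1000 nM, the highest of the three numbers. Compound 2 `COC(=O)C1=C(C)N=C(C)/C(=C(\O)OC)C1c1ccccc1C#N` gives 15.9 nM, and compound 3 `COC(=O)C1=C(C)N=C(C)/C(=C(\O)OC)C1c1cc([N+](=O)[O-])ccc1Cl` gives 30.2 nM; both stand well below compound 1, beyond the scatter.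

The new compound 4 `CCc1ccccc1C1C(C(=O)OC)=C(C)N=C(C)/C1=C(\O)OC` differs from compound 1 in one place: 2-ethylphenyl in place of 3-hydroxyphenyl on a saturated ring carbon. For the measured compounds named here, only one measured step bears directly on this change, the one from compound 1 to compound 2, which replaces the same 3-hydroxyphenyl with another aryl group and gives a 63-fold lower number from compound 1 to compound 2 (1.80 log units; beyond the scatter). The pair of compound 1 and compound 3, though not a single-place step, also shows that exchanging the 3-hydroxyphenyl for a differently substituted phenyl goes with a far lower number.

On that basis a large drop is expected again, of about a 33-fold lower number from compound 1 to compound 4 (1.52 log units; beyond the scatter). Compound 4 is therefore estimated at 30 nM, within a range of 8 nM to 120 nM.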

Compound 4, half-maximal effective concentration: 6.46 nM
Beside the measured number, compound 4's estimate is 4.6-fold (0.67 log units) above it; measured number outside the range, below it.
By their numbers in this assay, from the lowest: compound 4; then compounds 2 and 3 (each within the scatter of the next); then compound 1.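

In this assay, 2-ethylphenyl in place of 3-hydroxyphenyl gives a 150-fold lower number from compound 1 to compound 4 (2.19 log units; beyond the scatter) and so shows that this saturated ring carbon can carry an aryl group with 0 hydrogen-bond donors and 0 hydrogen-bond acceptors and still give a low number. Ethyl in place of cyano on the aromatic carbon gives a 2.5-fold lower number from compound 2 to compound 4 (0.39 log units; beyond the scatter) and so adds a modest step beyond the scatter. A nitrile is therefore not needed on that aromatic carbon for a low number, and a group made only of carbon gives a lower one.

No measurement here explains either step. Open, as far as these compounds go, is whether a longer chain, a methyl group or an amine in the place of the ethyl would keep the number this low, and how much of the step from compound 1 comes from the group itself rather than from where it sits on the phenyl ring.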